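This account rests on a few compounds, and the source may have more. Where it says the series, first, only, none or still open, it means among the compounds named here.

Measured so far in a functional assay on MDA-MB-231 cells (Homo sapiens) for inhibition, read by MTT assay, with a stated time of 72 h; on this read-out higher numbers stand for weaker inhibition and lower numbers for stronger inhibition:
- compound 1 `Cc1ccc(-c2cc(C(=O)N3CCC4(CC3)CC(=O)c3nn(C(C)(C)C)cc3O4)c3ccccc3n2)cc1`: > 10000 nM
- compound 2 `CC(C)(C)n1cc2c(n1)C(=O)CC1(CCN(C(=O)c3cc(-c4ccccc4Cl)nc4ccccc34)CC1)O2`: > 10000 nM
- compound 3 `CC(C)(C)n1cc2c(n1)C(=O)CC1(CCN(C(=O)c3cc(-c4ccc(F)cc4)nc4ccccc34)CC1)O2`: > 10000 nM

Each of these entries is a limit and not a number. Among the compounds with values here, the series so far sits at one point: the limit of > 10000 nM in this assay, at which 3 of the 3 values shown sit. Compound 3 therefore offers only its limit, > 10000 nM, as a starting point.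

The next compound is compound 4 `COc1ccc(-c2cc(C(=O)N3CCC4(CC3)CC(=O)c3nn(C(C)(C)C)cc3O4)c3ccccc3n2)cc1OC`, with this change: 3,4-dimethoxyphenyl in place of 4-fluorophenyl on an aromatic carbon. In words, 3,4-dimethoxyphenyl replaces 4-fluorophenyl on an aromatic carbon next to the ring nitrogen.

Three measured steps alter the group at this place: a step that the two limits leave unreadable from compound 1 to compound 2, a step that the two limits leave unreadable from compound 1 to compound 3 and a step that the two limits leave unreadable from compound 2 to compound 3. None has a readable size, so none supplies a size or direction to carry over to the new group. In this assay, no step beyond the scatter can be predicted, and compound 4 is expected to stay close to the same limit.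

The estimated step is a step that the limit leaves unreadable from compound 3 to compound 4. For compound 4 the estimated value is 15000 nM, with an expected range of 5000 nM to 50000 nM.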

Compound 4, half-maximal inhibitory concentration: 7130 nM
Compound 4: middle estimate off by 2.1-fold (0.32 log units), on the high side, and the stated range covers the measured number.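

In this assay compound 4 gives 7130 nM, the first entry at this place that is a number. The rest of the series stays at a limit: the limit of > 10000 nM in this assay, at which 3 of the 4 values shown sit.

Measured against those limits, 3,4-dimethoxyphenyl gives an at least 1.4-fold lower number from compound 3 to compound 4 (0.14 log units; that floor lies within the scatter), an at least 1.4-fold lower number from compound 2 to compound 4 (0.14 log units; that floor lies within the scatter) and an at least 1.4-fold lower number from compound 1 to compound 4 (0.14 log units; that floor lies within the scatter). Each of these is only a floor, so the true size of the step stays unknown and no step beyond the scatter is shown, while the steps among compound 1, compound 2 and compound 3 cannot be read.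

On these data alone, whether both methoxy groups are needed for a numerical reading remains open. Also open, as far as these compounds go, is what an amine or a carboxylic acid on this phenyl ring would give in this assay.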